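The compounds below may be only part of what the source reports. "The series", "measured", "known", "first", "only" and "open" are said of these compounds alone.

Measured so far:
compound 1, `COc1cc(OC)c(C(=O)/C=C/c2ccc(Cl)cc2)c(OC)c1`: 8200 nM
compound 2, `COc1cccc(/C=C/C(=O)c2c(O)cc(OC)cc2OC)c1`: 13200 nM
compound 3, `COc1cc(O)c(C(=O)/C=C/c2ccccc2SC)c(OC)c1`: a limit only, > 20000 nM

In a functional assay on MDA-MB-231 cells (Homo sapiens) for cytotoxicity, with a stated time of 48 h (on this read-out lower numbers stand for stronger inhibition and higher numbers for weaker inhibition), compound 1 gives 8200 nM. Compound 2 gives 13200 nM in this assay; this number lies close to that of compound 1, within the usual scatter, so the two cannot be put in order. For compound 3 this assay reports only a limit, > 20000 nM, and no number. Among the three results, one sits at the limit of > 20000 nM in this assay, at which 1 of the 3 values shown sits.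

Compound 4, `COc1cc(OC)c(C(=O)/C=C/c2ccc(F)cc2)c(OC)c1`, has not yet been measured in this assay. It differs from compound 1 in one place: fluoro in place of chloro on an aromatic carbon. Going by the values given here, no measured pair shows this kind of swap, so the expectation rests on the value of compound 1 alone. A change of this size, one halogen for another on the same aromatic carbon, is expected to move the number little, if at all, beyond the scatter, with a slight lean toward a higher number. Compound 4 is therefore expected to give about 11000 nM in this assay, somewhere between 4500 nM and 27000 nM, which means an expected step of a 1.3-fold higher number from compound 1 to compound 4 (0.13 log units; within the scatter).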

Compound 4, half-maximal inhibitory concentration: 10700 nM
Beside the measured number, compound 4's estimate is 1.0-fold (0.01 log units) above it; the measured number falls inside the stated range.
By their numbers in this assay, from the lowest: compounds 1, 4 and 2 (each within the scatter of the next). At a limit, above all of these: compound 3.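

In this assay, the swap from 4-chlorophenyl to 4-fluorophenyl gives a 1.3-fold higher number from compound 1 to compound 4 (0.12 log units; within the scatter) and is the first step shown between two measured compounds that differ in one place. At this position on an aromatic carbon, para to a large group, this read-out therefore cannot tell chloro and fluoro apart, so one halogen can replace the other without a change that stands out from repeat measurements. Nothing measured here bears on why the two halogens give such similar results.

As far as these compounds go, whether an amine, a carboxylic acid or a longer chain at this same place would move the number beyond the scatter remains open. Compound 2 and compound 3 each differ from compound 1 in more than one place, so they cannot settle this question.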